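The source may hold more compounds than are shown below. What is called first, only, known or untested is meant among the compounds shown, and "the series" means these compounds.

Of the compounds shown here, two built on a shared core have been measured in an assay on isolated protein for inhibition of tyrosine-protein kinase receptor UFO (Homo sapiens), read by TR-FRET, with a stated time of 60 min; on this read-out higher numbers stand for weaker inhibition and lower numbers for stronger inhibition. Compound 1 `CN1CCN(Cc2ccc(Nc3ncc(Cl)c(Nc4ccc(F)cc4S(=O)(=O)N4CCCC4)n3)cc2)CC1` gives 37 nM. Among the compounds with values here, compound 2 `CN1CCN(Cc2ccc(Nc3ncc(Cl)c(Nc4ccc(Cl)cc4S(=O)(=O)N4CCCC4)n3)cc2)CC1` carries chloro where compound 1 carries fluoro; in this assay compound 2 gives 1080 nM, so compound 2 stands highest of the two numbers, with compound 1 as its only neighbour. The step of a 29-fold higher number from compound 1 to compound 2 (1.47 log units; beyond the scatter) shows that this ring position is sensitive to what sits on it. Compound 3 `CN1CCN(Cc2ccc(Nc3ncc(Cl)c(Nc4ccc(O)cc4S(=O)(=O)N4CCCC4)n3)cc2)CC1` is not yet measured; it differs from compound 2 by hydroxy in place of chloro on an aromatic carbon. The one measured step gives only indirect guidance: a change at this spot can move the number a long way, but the direction for a hydroxy group is not shown. Compound 3 is therefore expected to give about 250 nM, within a range from 30 nM to 2000 nM. The expected step of a 4.3-fold lower number from compound 2 to compound 3 (0.64 log units; beyond the scatter) leans downward because compound 1, with its small fluoro group, gives 37 nM.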

Compound 3, half-maximal inhibitory concentration: 1320 nM
Beside the measured number, compound 3's estimate is 5.3-fold (0.72 log units) below it; the measured number falls inside the stated range.
By their numbers in this assay, from the lowest: compound 1; then compounds 2 and 3 (each within the scatter of the next).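

In this assay the change from chloro to hydroxy gives a 1.2-fold higher number from compound 2 to compound 3 (0.09 log units; within the scatter) so this position does not separate these two groups, even though hydroxy adds a hydrogen-bond donor and a hydrogen-bond acceptor that chloro lacks. Measured against fluoro, the same hydroxy group gives a 36-fold higher number from compound 1 to compound 3 (1.55 log units; beyond the scatter) so both replacements of fluoro shown here end up far from compound 1, and among these three compounds only the fluoro compound has the low number. Nothing available here explains why fluoro stands apart from chloro and hydroxy.

On these data alone, it remains open whether a plain hydrogen, a methoxy group or an amine at this position would fall close to compound 1 or close to compound 2 and compound 3. As far as these compounds go, it is also open whether the gap between fluoro and the other two groups would persist with changes elsewhere on the shared core.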